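A few compounds are considered here, and "the series" means these few. Any claim that something is new, unique, unknown or untested is made for them only; others in the source may bear on it.

Measured values in an in vitro functional assay on HEK293-A cells for positive allosteric modulation of metabotropic glutamate receptor 5 (Homo sapiens), read by fluorescence and calcium flux, with a stated time of 140 s; on this read-out higher numbers stand for an effect only at larger amounts of compound and lower numbers for an effect already at smaller amounts:
compound 1 `O=C(c1ccc(F)c(F)c1)N1CCCC[C@@H]1c1nc(-c2cccc(F)c2)no1`: 1400 nM
compound 2 `O=C(c1cccc(F)c1)N1CCCC[C@@H]1c1nc(-c2cccc(F)c2)no1`: 460 nM
compound 3 `O=C(c1ccc(F)c(F)c1)N1CCCC1c1nc(-c2cccc(F)c2)no1`: 3700 nM

Compound 3 gives the highest of the three numbers. The difference between the core of compound 3 and the core of compound 1 is not broken down here. Within the first core, the change hydrogen in place of fluoro on an aromatic carbon made a step of a 3.0-fold lower number from compound 1 to compound 2 (0.48 log units; beyond the scatter).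

Compound 4 `O=C(c1cccc(F)c1)N1CCCC1c1nc(-c2cccc(F)c2)no1` is the not yet measured partner of compound 3, differing by hydrogen in place of fluoro on an aromatic carbon. This is the same change as from compound 1 to compound 2, at a place described in the same words. For compound 4 a step of a 3.1-fold lower number from compound 3 to compound 4 (0.49 log units; beyond the scatter) is expected in this assay, resting on the step of a 3.0-fold lower number from compound 1 to compound 2 (0.48 log units; beyond the scatter) seen for the same change. Compound 4 is therefore estimated at 1200 nM, expected to fall between 600 nM and 2500 nM.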

Compound 4, half-maximal effective concentration: 2600 nM
For compound 4 the middle estimate is 2.2-fold (0.34 log units) below the measured one, and the stated range ends below it.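

In this assay, the change from 3,4-difluorophenyl to 3-fluorophenyl gives a 1.4-fold lower number from compound 3 to compound 4 (0.15 log units; within the scatter), so on this core the change alone does not separate the pair. Set beside the earlier step, the two results cannot be told apart: the same change on two cores in this assay, a 3.0-fold lower number (0.48 log units; beyond the scatter) from compound 1 to compound 2 and a 1.4-fold lower number (0.15 log units; within the scatter) from compound 3 to compound 4, 2.1-fold (0.33 log units) apart, within the scatter of two such steps. The change can therefore be carried across these two cores without a detectable difference in step size, but with one pair per core this does not show that the step is the same on both, nor that it would hold on any other core.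

Still open, as far as these compounds go, is how chloro, methyl, methoxy or nitrile would behave on the same aromatic carbon. The compounds shown also leave open whether the step persists on cores beyond these two.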